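The source may report more compounds than this note shows. Statements on the series, on what has been measured and on what is new or still open speak of the compounds shown alone.

Measured so far:
compound 1 `CN1C[C@H](C(=O)Nc2ccc(F)cc2)[C@@H](c2ccc(/C=C/C(=O)Nc3ccccc3N)cc2)C1` gives 34 mL/min/kg
compound 2 `Cc1cc(NC(=O)[C@H]2CN(C)C[C@@H]2c2ccc(/C=C/C(=O)Nc3ccccc3N)cc2)ccc1F` gives 62 mL/min/kg
compound 3 `CN1C[C@H](C(=O)Nc2cccnc2)[C@@H](c2ccc(/C=C/C(=O)Nc3ccccc3N)cc2)C1` gives 41 mL/min/kg

These three compounds were tested in an in vitro ADME assay on microsomes from liver (Mus musculus) for pharmacokinetics, read by LC-MS, with a stated time of 10 min, tested at 1 uM; a higher number here means faster removal of the compound, a lower number slower removal. Compound 1 and compound 2 share one core and differ only in the change (methyl in place of hydrogen on an aromatic carbon). That change made the step of a 1.8-fold higher number from compound 1 to compound 2 (0.26 log units; within the scatter).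

Compound 3 carries a different group on the amide-type nitrogen; the difference between the core of compound 1 and the core of compound 3 is pyridin-3-yl in place of 4-fluorophenyl on an amide-type nitrogen. Compound 4 `Cc1ccc(NC(=O)[C@H]2CN(C)C[C@@H]2c2ccc(/C=C/C(=O)Nc3ccccc3N)cc2)cn1` has not yet been measured in this assay. It differs from compound 3 by methyl in place of hydrogen on an aromatic carbon. In words this is the same change that was made from compound 1 to compound 2, but the place is not the same: in compound 2 the methyl sits on a six-membered aromatic ring of carbon only, ortho to a fluoro group and meta to a large group, whereas in compound 4 it sits on a six-membered aromatic ring with 1 nitrogen, next to the ring nitrogen and para to a large group. It is therefore the same kind of change, not the same change.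

For compound 4 the expected step, set beside the earlier one, is a 1.3-fold higher number from compound 3 to compound 4 (0.13 log units; within the scatter). That expectation rests on the step of a 1.8-fold higher number from compound 1 to compound 2 (0.26 log units; within the scatter), allowing for the different ring around the methyl. It also rests on the value of compound 3, 41 mL/min/kg. The estimate for compound 4 is 55 mL/min/kg, expected to lie between 30 mL/min/kg and 100 mL/min/kg.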

Compound 4, clearance: 57 mL/min/kg
Compound 4: middle estimate off by 1.0-fold (0.02 log units), on the low side, within the range that was stated.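

In this assay, a methyl on the pyridin-3-yl group gives a 1.4-fold higher number from compound 3 to compound 4 (0.14 log units; within the scatter), and this step can be set beside the one for the same kind of change on the other core: the same change on two cores in this assay, a 1.8-fold higher number (0.26 log units; within the scatter) from compound 1 to compound 2 and a 1.4-fold higher number (0.14 log units; within the scatter) from compound 3 to compound 4, 1.3-fold (0.12 log units) apart, within the scatter of two such steps. The two steps cannot be told apart, which fits the idea that this change carries from one core to the other, but each step is itself within the scatter, so only one pair of steps supports it and no real effect of the methyl is shown on either core. Nor do the full group swaps on the amide-type nitrogen separate the compounds, with a 1.1-fold lower number from compound 2 to compound 4 (0.04 log units; within the scatter) and a 1.7-fold higher number from compound 1 to compound 4 (0.22 log units; within the scatter), so compound 4 cannot be ranked against compound 1 or compound 2.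

The compounds shown leave open whether a different group at the place next to the ring nitrogen, such as ethyl, methoxy or an amine, would move clearance beyond the scatter. They also leave open how a methyl would behave at any other place on the six-membered aromatic ring with 1 nitrogen, or on a core beyond these two.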